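Methylsulfanyl in Place of Carboxymethoxy: Expected Cytotoxicity

The compounds below may be only part of what the source reports. "The series", "measured", "known", "first", "only" and "open" are said of these compounds alone.

Compound 1 `CCCCC(c1cc2ccc(C)cc2[nH]c1=O)N(Cc1ccc(F)cc1)Cc1ccc(C(C)C)cc1`: > 33000 nM in a toxicity assay on MDCK cells (Canis lupus familiaris) for cytotoxicity, read by crystal violet staining, with a stated time of 48 h (on this read-out higher numbers stand for lower toxicity in this test and lower numbers for higher toxicity in this test), a limit of the test.
Compound 2 `Cc1ccc2[nH]c(=O)c(CN(Cc3ccc(OCC(=O)O)cc3)Cc3ccc(C(C)(C)C)cc3)cc2c1`: > 10000 nM in this assay, a limit of the test.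
Compound 3 `CCc1ccc2[nH]c(=O)c(CN(Cc3ccc(OC(F)F)cc3)Cc3ccc(C(C)(C)C)cc3)cc2c1`: > 5000 nM in this assay, a limit of the test.

For compound 2 the value is a limit, not a measured number. Each of the other two compounds also gave only a limit, so no order among the three can be drawn. Compound 4 `CSc1ccc(CN(Cc2ccc(C(C)(C)C)cc2)Cc2cc3cc(C)ccc3[nH]c2=O)cc1` differs from compound 2 by methylsulfanyl in place of carboxymethoxy on an aromatic carbon. Among the measured compounds shown here, no two measured compounds differ in a single place, so there is no measured step to lean on. The expected step from compound 2 to compound 4 in this assay is a step that the limit leaves unreadable from compound 2 to compound 4, which is none beyond the scatter. Compound 4 is estimated at 20000 nM, with a range from 8000 nM to 50000 nM, and the test is expected most likely to return only a limit again.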

Compound 4, half-maximal cytotoxic concentration: > 5000 nM
Compound 4: a limit, no number; the forecaster's own chance of this, stated with the estimate: 70%; the middle value does not contradict the limit.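

Compound 2 and compound 4 each gave only a limit in this assay, so no step can be read between them. The compounds shown leave open the concentration at which any of them becomes toxic to these cells.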